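This account rests on a few compounds, and the source may have more. Where it says the series, first, only, none or still open, it means among the compounds named here.

Measured compounds:
- compound 1, `N#CC1=C(N)N(c2ccc(S(N)(=O)=O)cc2)C2=C(C(=O)CCC2)C1c1ccccc1`: 30%
- compound 2, `COc1ccc2ccccc2c1C1C(C#N)=C(N)N(c2ccc(S(N)(=O)=O)cc2)C2=C1C(=O)CCC2`: 62%

Both were tested in a functional assay on Ehrlich cells (Mus musculus) for antiproliferative activity, read by trypan blue exclusion, with a stated time of 2 h, tested at 25 ug/mL; on this read-out lower numbers stand for a weaker effect and higher numbers for a stronger effect at the one concentration tested. Within the data shown here, compound 1 has the lower of the two numbers; its only neighbour is compound 2, and the step from one to the other, a number 32 percentage points higher from compound 1 to compound 2 (beyond the scatter), is large and lies beyond the scatter. It comes from a single change on the shared core, namely 2-methoxynaphthalen-1-yl in place of phenyl on a saturated ring carbon.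

Compound 3, `Cc1ccoc1C1C(C#N)=C(N)N(c2ccc(S(N)(=O)=O)cc2)C2=C1C(=O)CCC2`, has not yet been measured. It differs from compound 1 at the same saturated ring carbon: 3-methylfuran-2-yl in place of phenyl on a saturated ring carbon. Among the measured compounds shown here, the one measured step at this position shows that replacing phenyl there can raise the read-out strongly, but that step introduced a different group, so it offers only loose guidance here; no measured step tells how a 3-methylfuran-2-yl group behaves on this core. On that basis only a small upward step, a number 8 percentage points higher from compound 1 to compound 3 (within the scatter), is expected, and it may well stay within the scatter. Compound 3 is therefore estimated at 38%, with a range from 18% to 60%.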

Compound 3, a percentage reported as activity, at one concentration (the size of the read-out at that concentration, not a potency): 10%
Estimate against measurement, compound 3: 28 percentage points above; measured number below the stated range.
By their numbers in this assay, from the lowest: compound 3; then compound 1; then compound 2.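

Replacing phenyl with 3-methylfuran-2-yl on the saturated ring carbon gives, in this assay, a number 20 percentage points lower from compound 1 to compound 3 (beyond the scatter), so changing the group here can lower the read-out as well as raise it. The phenyl that leaves and the 3-methylfuran-2-yl that enters both have 6 heavy atoms, so heavy-atom count alone does not separate their results, and the range at this one carbon now reaches a number 52 percentage points lower from compound 2 to compound 3 (beyond the scatter). Nothing available explains the drop.

The compounds shown leave open whether the lower number goes with the furan ring itself or with its methyl group, a question that a plain furan-2-yl group on the same carbon could help to answer. Also open, on these data alone, is how a non-aromatic group such as cyclohexyl, or a phenyl ring carrying an amine or a carboxylic acid, would read at this carbon.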